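Replacing 3,5-dimethylphenyl in compound 2

The compounds below may be only part of what the source reports. "The series", "measured", "known", "first", "only" and "open" are said of these compounds alone.

Of the compounds shown here, two have numbers so far. In a functional assay on DU-145 cells (Homo sapiens) for inhibition, read by trypan blue exclusion, with a stated time of 96 h (on this read-out higher numbers stand for weaker inhibition of growth and lower numbers for stronger inhibition of growth), compound 1 (`Cc1ccsc1/C=C(/SCc1ccc(Cl)cc1)C(=O)c1ccc(Cl)cc1`) gives 50000 nM. Compound 2 (`Cc1cc(C)cc(/C=C(/SCc2ccc(Cl)cc2)C(=O)c2ccc(Cl)cc2)c1`) gives 10000 nM, the lower of the two numbers.

The next compound is compound 3 (`O=C(/C(=C\c1cccc(Cl)c1Cl)SCc1ccc(Cl)cc1)c1ccc(Cl)cc1`). It carries 2,3-dichlorophenyl in place of 3,5-dimethylphenyl on a double-bonded chain carbon bound to a double-bonded chain carbon. The rest of the structure stays the same.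

Among the measured compounds shown here, only one measured step bears on this change: a 5.0-fold lower number from compound 1 to compound 2 (0.70 log units; beyond the scatter). That modest step falls at the same place on the chain, but it involves 3-methylthiophen-2-yl and 3,5-dimethylphenyl, so it offers only a rough guide to size. For the measured compounds named here, no compound carrying 2,3-dichlorophenyl has been measured, and a single step gives no firm direction for the new group. A change beyond the scatter in this assay is therefore not expected, though a slightly lower number is the working guess. The expected change is a 1.4-fold lower number from compound 2 to compound 3 (0.15 log units; within the scatter). In this assay the estimate for compound 3 is 7000 nM, with an expected range of 2000 nM to 25000 nM.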

Compound 3, concentration for 50% growth inhibition: 10000 nM
Beside the measured number, compound 3's estimate is 1.4-fold (0.15 log units) below it; the measured number falls inside the stated range.
By their numbers in this assay, from the lowest: compounds 2 and 3 (each within the scatter of the next); then compound 1.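

In this assay, 2,3-dichlorophenyl in place of 3,5-dimethylphenyl on a double-bonded chain carbon bound to a double-bonded chain carbon gives no change at the digits printed from compound 2 to compound 3 (within the scatter) and so adds a second phenyl group that this read-out does not separate from the first, although the two groups share neither their substituent atoms nor their naming positions. The comparison with the thiophene compound now rests on two phenyl groups: 2,3-dichlorophenyl gives a 5.0-fold lower number from compound 1 to compound 3 (0.70 log units; beyond the scatter) and 3,5-dimethylphenyl gives a 5.0-fold lower number from compound 1 to compound 2 (0.70 log units; beyond the scatter) in the same place, so among these three compounds, compound 1 alone stands apart. Nothing on hand accounts for either the match between the two phenyl compounds or the gap to the thiophene compound.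

Still open, going by these compounds, is whether the kind of substituent or its placement matters here, as compound 2 and compound 3 differ in both, and 3,5-dichlorophenyl or 2,3-dimethylphenyl would separate the two. Also open, on these data alone, is how this position responds to a plain phenyl or to a phenyl ring carrying a carboxylic acid or an amine, and whether any change elsewhere on the shared core moves the number further.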